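A few compounds are considered here, and "the series" means these few. Any claim that something is new, unique, unknown or untested is made for them only; others in the source may bear on it.

Of the compounds shown here, two built on a shared core have numbers so far in a functional assay on HT-29 cells (Homo sapiens) for inhibition, read by luminescence and CellTiter-Glo, with a stated time of 24 h; a lower number here means that less compound is needed, a higher number that more compound is needed for the effect. Compound 1 (`CN1C(=S)[C@@H](NC(=O)c2nc(Cc3ccccc3)n(CCCC(F)(F)F)n2)COc2ccccc21`), with a trifluoromethyl group on its chain, gives 2380 nM. Compound 2 (`CN1C(=S)[C@@H](NC(=O)c2nc(Cc3ccccc3)n(CCCCC#N)n2)COc2ccccc21`), which bears a 4-cyanobutyl group, gives 2680 nM. Going by the values given here, the only measured step is a 1.1-fold higher number from compound 1 to compound 2 (0.05 log units; within the scatter). It lies within the scatter, so compound 2 stands level with compound 1 and the two cannot be ranked.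

Compound 3 (`CN1C(=S)[C@@H](NC(=O)c2nc(Cc3ccccc3)n(C3CCCCCC3)n2)COc2ccccc21`) has not yet been measured in this assay. It carries cycloheptyl in place of 4-cyanobutyl on an aromatic nitrogen. This replaces the whole open chain with a ring, a larger change than the one measured so far. Among the compounds with values here, the measured step, a 1.1-fold higher number from compound 1 to compound 2 (0.05 log units; within the scatter), suggests only that this group can vary on its chain without a visible shift. Within the data shown here, no measured compound has a ring at this place, so the direction remains open. The expected change is therefore no step beyond the scatter, and the estimate is a 1.2-fold lower number from compound 2 to compound 3 (0.09 log units; within the scatter). For compound 3 the estimated value is 2200 nM, with an expected range from 600 nM to 8000 nM.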

Compound 3, half-maximal effective concentration: 5530 nM
Compound 3: the middle estimate sits 2.5-fold (0.40 log units) below what was measured; the range from low to high includes it.
By their numbers in this assay, from the lowest: compounds 1 and 2 (each within the scatter of the next); then compound 3.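

In this assay, replacing an open chain with a ring on this aromatic nitrogen gives the first shift beyond the scatter in the series: a 2.1-fold higher number from compound 2 to compound 3 (0.31 log units; beyond the scatter), and against the fluorinated chain, a 2.3-fold higher number from compound 1 to compound 3 (0.37 log units; beyond the scatter). Both steps are modest, but they show that this position is not indifferent to what it carries: 4-cyanobutyl and 4,4,4-trifluorobutyl stand level with each other, while cycloheptyl, with its seven-membered ring of carbon only, needs more compound for the effect. Nothing available explains this shift.

The compounds shown cannot separate the effect of having a ring from the effect of losing the nitrile or the fluorines, since cycloheptyl differs from each chain in both ways at once. A plain pentyl chain of carbon only, a smaller cyclopentyl ring, or a chain ending in an amine would help show which of these differences matters and whether a smaller ring sits closer to the open chains or to cycloheptyl.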